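Series notes: from compound 2 to an untested analogue

A few compounds are considered here, and "the series" means these few. Any claim that something is new, unique, unknown or untested is made for them only; others in the source may bear on it.

Of the compounds shown here, two carry numbers so far. Compound 1 `CC(C)(C)N(NC(=O)c1ccccc1)C(=O)c1ccccc1C(F)(F)F` in an assay on cells for agonist activity at ecdysone receptor (Bombyx mori), read by a luciferase reporter, with a stated time of 24 h (a higher number here means that more compound is needed for the effect, a lower number that less compound is needed), gives 631 nM. Compound 2 `CC(C)(C)N(NC(=O)c1cccc(Br)c1)C(=O)c1ccccc1Cl` in this assay gives 191 nM, the lowest of the two numbers, and its gap to compound 1 lies beyond the usual scatter. Within the data shown here, no single-point step between the two is available, as they differ in more than one place.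

Compound 3 `Cc1ccc(C(=O)NN(C(=O)c2ccccc2Cl)C(C)(C)C)cc1C` differs from compound 2 in one place: 3,4-dimethylphenyl in place of 3-bromophenyl on a carbonyl carbon. Among the measured compounds shown here, no measured pair isolates this change, so the expectation is loose. The change sits on a carbonyl carbon whose other neighbours are an amide-type nitrogen, and the number is expected to stay in the same region, possibly somewhat lower; the estimated step in this assay is a 1.6-fold lower number from compound 2 to compound 3 (0.20 log units; within the scatter). For compound 3 in this assay the estimate is 120 nM, with a range from 40 nM to 400 nM.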

Compound 3, half-maximal effective concentration: 87.1 nM
Compound 3: the middle estimate sits 1.4-fold (0.14 log units) above what was measured, within the range that was stated.
By their numbers in this assay, from the lowest: compound 3; then compound 2; then compound 1.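

In this assay, among these compounds, 3,4-dimethylphenyl in place of 3-bromophenyl on a carbonyl carbon gives a 2.2-fold lower number from compound 2 to compound 3 (0.34 log units; beyond the scatter), the first step that isolates a single place. At this position, then, the bromine is not needed to keep the number low, and a group of carbon only does the job with the 2-chlorobenzoyl side held constant. Nothing at hand bears on why the number moves.

Still open, as far as these compounds go, is whether the step belongs to the loss of bromine or to the entry of the two methyl groups, a question that a 3-methylphenyl or a 4-methylphenyl group on the same carbonyl carbon would separate. From the compounds shown here alone, how this position responds to a group of a different kind, such as an aminophenyl or a carboxyphenyl, also remains open.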